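The compounds below may be only part of what the source reports. "The series", "measured", "known", "first", "only" and "open" are said of these compounds alone.

In a functional assay on a cell-free system (Platelet, plasma, Oryctolagus cuniculus) for inhibition, with a stated time of 5 min (a higher number here means a weaker inhibitor, a lower number a stronger inhibitor), three compounds have been tested so far. Compound 1 `COC(=O)c1ccc(OCc2nc(C)c(C)nc2C)c(OC)c1` gives > 2000000 nM as its result, which is a limit of the assay and not a number. Compound 2 `COc1cc(C(=O)O)ccc1OCc1nc(C)c(C)nc1C` gives > 2000000 nM as its result, again a limit. Compound 3 `Cc1nc(C)c(COC(=O)CCCC[C@@H]2CCSS2)nc1C` gives > 2000000 nM as its result, also a limit. Compound 2 therefore has no number of its own and stands with the other two, as the limit of > 2000000 nM in this assay, at which 3 of the 3 values shown sit, makes clear.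

Compound 4 `C=CCc1ccc(OCc2nc(C)c(C)nc2C)c(OC)c1` differs from compound 2 in one place, with allyl in place of carboxy on an aromatic carbon. Within the data shown here, the only measured step that touches this carboxy group is a step that the two limits leave unreadable from compound 1 to compound 2 and it offers no size to carry over. No readable step therefore supports a clear gain or loss, so the expectation stays close to the result of compound 2 at > 2000000 nM as its only anchor, itself a limit. The expected outcome is a number no higher from compound 2 to compound 4 (the limit leaves the size open) in this assay as an estimate, meaning no change beyond the scatter. For compound 4 the estimated value is 2000000 nM with an expected range from 300000 nM to 4000000 nM and a real chance of only a limit.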

Compound 4, half-maximal inhibitory concentration: > 2000000 nM
Compound 4 ended at the assay's limit; the forecaster's own chance of this, stated with the estimate: 60%; the middle value lies on the limit itself.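

Compound 4 gives a limit and not a number, as do compound 1 and compound 2, so the steps among these three compounds cannot be read and no size can be taken from them. The compounds shown leave open what change, if any, would give a measurable result in this assay, as all results stand at one point: the limit of > 2000000 nM in this assay, at which 4 of the 4 values shown sit.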